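Oxadiazole to tetrazole swap on the biaryl tail

The source may report more compounds than this note shows. Statements on the series, on what has been measured and on what is new or still open speak of the compounds shown alone.

Compound 1 `C[C@@H](Nc1nccc(Cl)c1NC(=O)CC#N)c1ccc(-c2cccc(F)c2C(F)(F)F)cc1` carries the shared core with an unsubstituted trifluoromethyl-fluoro biaryl tail; in a functional assay on CHO cells for antagonist activity at B1 bradykinin receptor (Homo sapiens), read by FLIPR and calcium flux (a lower number here means a stronger inhibitor, a higher number a weaker inhibitor), compound 1 gives "not determined" (no result reported), so it gives no number to compare. Compound 2 `Cc1noc(-c2c(F)cccc2-c2ccc([C@@H](C)Nc3nccc(Cl)c3NC(=O)CC#N)cc2)n1` replaces that trifluoromethyl with a 3-methyl-1,2,4-oxadiazol-5-yl group, and in this assay compound 2 gives 0.94 nM. Within the series this is the only number shown, so compound 2 is the sole reference point; no steps between measured compounds exist here.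

Compound 3 `C[C@@H](Nc1nccc(Cl)c1NC(=O)CC#N)c1ccc(-c2cccc(F)c2-c2nnn(C)n2)cc1` is the next member and is to be measured in this assay. It differs from compound 2 in one place: 2-methyl-2H-tetrazol-5-yl in place of 3-methyl-1,2,4-oxadiazol-5-yl on an aromatic carbon. The group that leaves and the group that enters match in heavy-atom count and both are methyl-bearing five-membered aromatic rings, the entering ring holding one more hetero atom and one more hydrogen-bond acceptor.

For the measured compounds named here, with no measured step available for this kind of change, the expectation is a step from compound 2 to compound 3 of a 1.6-fold higher number from compound 2 to compound 3 (0.20 log units; within the scatter), within or close to the usual scatter. Compound 3 is therefore estimated at 1.5 nM in this assay, with a range of 0.5 nM to 5 nM.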

Compound 3, half-maximal inhibitory concentration: 1.17 nM
Compound 3: middle estimate off by 1.3-fold (0.11 log units), on the high side; measured number inside the range.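

In this assay, the exchange of 3-methyl-1,2,4-oxadiazol-5-yl for 2-methyl-2H-tetrazol-5-yl gives a 1.2-fold higher number from compound 2 to compound 3 (0.10 log units; within the scatter), so the two rings cannot be told apart on this read-out. For the compounds shown here, this is the first step that can be read at this position, on an aromatic carbon ortho to a fluoro group and ortho to a large group, and it shows that a sub-nanomolar-range number does not depend on the oxadiazole ring alone: the two rings differ in hetero atoms and hydrogen-bond acceptors, yet their numbers lie within the scatter of each other. Nothing measured here explains why the two rings read alike.

As far as these compounds go, the step from the trifluoromethyl group cannot be read, as compound 1 gives "not determined" (no result reported), so it remains open how a group other than a methyl-bearing five-membered aromatic ring compares at this position. Also open, from the compounds shown here alone, is whether this single pair extends to a carboxylic acid, a primary amide or an ethyl in place of the methyl on the ring.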